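A Methoxy Group Added to the Phenyl Ring of Compound 2

A few compounds are considered here, and "the series" means these few. Any claim that something is new, unique, unknown or untested is made for them only; others in the source may bear on it.

The compounds measured so far:
compound 1, `CCN1CCN(CC(=O)Nc2nc3ccccc3[nH]2)CC1`, gives 65.8% in a functional assay, read by spectrophotometry, with a stated time of 30 min, tested at 200 ug/mL; on this read-out higher numbers stand for a stronger effect at the one concentration tested and lower numbers for a weaker effect
compound 2, `O=C(CN1CCN(c2ccccc2)CC1)Nc1nc2ccccc2[nH]1`, gives 62.1%
compound 3, `O=C(CN1CCN(c2ncccn2)CC1)Nc1nc2ccccc2[nH]1`, gives 81.8%

Compound 2 has the lowest of the three numbers in this assay. Its nearest neighbour is compound 1, and the difference between them is within the scatter: a number 3.7 percentage points lower from compound 1 to compound 2 (within the scatter). Compound 3 is the only one beyond the scatter from it: a number 19.7 percentage points higher from compound 2 to compound 3 (beyond the scatter). The third step, from the ethyl group to the pyrimidin-2-yl group, is of similar size: a number 16 percentage points higher from compound 1 to compound 3 (beyond the scatter).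

Compound 4, `COc1ccccc1N1CCN(CC(=O)Nc2nc3ccccc3[nH]2)CC1`, has not yet been measured. It differs from compound 2 in one place: methoxy in place of hydrogen on an aromatic carbon. The three measured steps all exchange the entire group on the ring nitrogen; none of them adds a substituent to the phenyl ring while keeping it in place. They therefore give no direct guide, and a small change is the most cautious expectation. Compound 4 is expected to show a number 2.9 percentage points higher from compound 2 to compound 4 (within the scatter), that is, no step beyond the scatter. The estimate for compound 4 in this assay is 65%, with a likely range from 48% to 80%.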

Compound 4, a percentage reported as activity, at one concentration (the size of the read-out at that concentration, not a potency): 64.5%
The estimate for compound 4 lay 0.5 percentage points above the measured number; low and high end bracket the measured number.
By their numbers in this assay, from the lowest: compounds 2, 4 and 1 (each within the scatter of the next); then compound 3.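

In this assay, putting a substituent on the phenyl ring of compound 2 while keeping the ring in place gives a change that cannot be told from the scatter: methoxy in place of hydrogen on an aromatic carbon, ortho to a large group, gives a number 2.4 percentage points higher from compound 2 to compound 4 (within the scatter) in this series. Within the data shown here, the earlier steps all exchanged the entire group on the ring nitrogen, so this is the first sign that this aromatic carbon can carry a methoxy group without a clear shift in the read-out. The 2-methoxyphenyl group also remains clearly apart from the pyrimidin-2-yl group (a number 17.3 percentage points lower from compound 3 to compound 4 (beyond the scatter)) and cannot be told apart from the ethyl group (a number 1.3 percentage points lower from compound 1 to compound 4 (within the scatter)), so adding methoxy does not close the gap to compound 3.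

No measured property of these compounds is available to account for this result. From the compounds shown here alone, it remains open whether another group on that same aromatic carbon, such as a chlorine atom, an amine or a carboxylic acid, would also stay within the scatter of compound 2.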